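A hydroxy-dimethylphenyl variant of a fluorophenyl chromone

The source may hold more compounds than are shown below. What is called first, only, known or untested is meant among the compounds shown, and "the series" means these compounds.

Compound 2 `CCC1=C(O)c2c(oc(-c3ccc(F)cc3)cc2=O)C(CC)(CC)C1=O` gives 1.85 uM in a functional assay on KBVIN cells (Homo sapiens) for antiproliferative activity, read by sulforhodamine B assay, with a stated time of 3 days (a higher number here means that more compound is needed for the effect, a lower number that less compound is needed), the second highest of the three numbers shown: compound 3 `CCC1=C(O)c2c(oc(-c3ccc(OC)c(OC)c3OC)cc2=O)C(CC)(CC)C1=O` gives 1.57 uM in this assay, within the scatter of compound 2, while compound 1 `CCCOc1ccc(-c2cc(=O)c3c(o2)C(CC)(CC)C(=O)C(CC)=C3O)cc1` gives 29.2 uM, a large step of a 16-fold lower number from compound 1 to compound 2 (1.20 log units; beyond the scatter) by fluoro in place of propoxy on an aromatic carbon. Compound 4 `CCC1=C(O)c2c(oc(-c3ccc(O)c(C)c3C)cc2=O)C(CC)(CC)C1=O` differs from compound 2 by 4-hydroxy-2,3-dimethylphenyl in place of 4-fluorophenyl on an aromatic carbon. Among the compounds with values here, no measured step covers this change; compound 3 shows only that other substitution on that ring sits within the scatter of compound 2. Compound 4 is therefore expected to stay near compound 2, with an estimated step of a 1.6-fold higher number from compound 2 to compound 4 (0.21 log units; within the scatter) in this assay. Compound 4 is estimated at 3 uM in this assay, between 0.8 uM and 12 uM.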

Compound 4, concentration for half-maximal effect: 2.75 uM
For compound 4 the middle estimate is 1.1-fold (0.04 log units) above the measured one; the measured number falls inside the stated range.
By their numbers in this assay, from the lowest: compounds 3, 2 and 4 (each within the scatter of the next); then compound 1.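

In this assay, the change to 4-hydroxy-2,3-dimethylphenyl gives a 1.5-fold higher number from compound 2 to compound 4 (0.17 log units; within the scatter) and so stays within the scatter, which shows that this position accepts a ring with a hydrogen-bond donor and more heavy atoms than 4-fluorophenyl. Compound 4 therefore stands with compound 2 and compound 3, far from compound 1 at 29.2 uM in this assay. Nothing measured here explains why this step is so small. The compounds shown leave open how much the hydroxy and the two methyl groups each contribute, and whether an amine or a carboxylic acid on this ring would also stay within the scatter of compound 2.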